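This account rests on a few compounds, and the source may have more. Where it says the series, first, only, none or still open, it means among the compounds named here.

Compound 1 `Cc1cc(Nc2cc(-c3ccccc3)[nH]n2)n2nc(SCc3ccc([N+](=O)[O-])cc3)nc2n1`: 43600 nM
Compound 2 `COc1ccc(CSc2nc3nc(C)cc(Nc4cc(-c5ccccc5)[nH]n4)n3n2)cc1`: 28200 nM
Compound 3 `Cc1cc(Nc2cc(-c3ccccc3)[nH]n2)n2nc(SCc3csc4ccccc34)nc2n1`: 29200 nM

All three were tested in an ADME assay on GES1 cells (Homo sapiens) for inhibition, read by MTT assay, with a stated time of 72 h; a higher number here means a weaker inhibitor, a lower number a stronger inhibitor. Compound 3 stands among the three numbers with no gap beyond the scatter: a 1.0-fold higher number from compound 2 to compound 3 (0.02 log units; within the scatter) and a 1.5-fold lower number from compound 1 to compound 3 (0.17 log units; within the scatter). Compound 4 `Cc1cc(Nc2cc(-c3ccccc3)[nH]n2)n2nc(SCC3CC3)nc2n1` has not been measured and keeps the shared core of compound 3. The change is cyclopropyl in place of 1-benzothiophen-3-yl on a saturated chain carbon bound to a sulfur, with cyclopropyl in place of 1-benzothiophen-3-yl on a saturated chain carbon bound to a sulfur. Both measured steps at this place stayed within the scatter, although neither tested a group like cyclopropyl, so no clear shift in either direction is expected in this assay. The estimated change is a 1.2-fold higher number from compound 3 to compound 4 (0.08 log units; within the scatter). For compound 4 the expected value is 35000 nM, with an estimated range of 17000 nM to 70000 nM.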

Compound 4, half-maximal inhibitory concentration: > 50000 nM
Compound 4 ended at the assay's limit; the forecaster's own chance of this, stated with the estimate: 15%; middle value at least 1.4-fold (0.15 log units) away from the limit.
By their numbers in this assay, from the lowest: compounds 2, 3 and 1 (each within the scatter of the next). At a limit, above all of these: compound 4.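

In this assay compound 4 gives > 50000 nM, which is a limit of the assay and not a number: the limit of > 50000 nM in this assay, at which 1 of the 4 values shown sits. Cyclopropyl, the only non-aromatic group shown on this saturated chain carbon bound to a sulfur, gives an at least 1.7-fold higher number from compound 3 to compound 4 (0.23 log units; that floor lies within the scatter), an at least 1.7-fold higher number from compound 2 to compound 4 (0.24 log units; that floor lies within the scatter) and an at least 1.1-fold higher number from compound 1 to compound 4 (0.05 log units; that floor lies within the scatter). From the compounds shown here alone, each floor lies within the scatter, so the true size of each step stays unknown.

Still open, going by these compounds, is how an amine, a carboxylic acid or a longer chain would read here, and whether any group at this place moves the number beyond the scatter.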